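The source may report more compounds than this note shows. Statements on the series, on what has been measured and on what is new or still open speak of the compounds shown alone.

Measured so far:
- compound 1 `Cc1ncc([N+](=O)[O-])n1CC(O)CSC(=S)N1CCCC1` — 1340000 nM
- compound 2 `CCN1CCN(CC(O)Cn2c([N+](=O)[O-])cnc2C)CC1` — 4940000 nM

Of the compounds shown here, two built on the same nitroimidazole-bearing core have been tested in a toxicity assay on HeLa cells (Homo sapiens) for cytotoxicity, read by MTT assay, with a stated time of 24 h; a higher number here means a weaker inhibitor, a lower number a stronger inhibitor. Compound 1 `Cc1ncc([N+](=O)[O-])n1CC(O)CSC(=S)N1CCCC1` gives 1340000 nM in this assay. Compound 2 `CCN1CCN(CC(O)Cn2c([N+](=O)[O-])cnc2C)CC1` carries a piperazine ring in place of the dithiocarbamate of compound 1. In this assay compound 2 gives 4940000 nM, the higher of the two numbers and therefore the weaker inhibitor of the pair, with a gap to compound 1 that lies beyond the usual scatter.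

Compound 3 `COc1ccccc1N1CCN(CC(O)Cn2c([N+](=O)[O-])cnc2C)CC1` has not yet been measured in this assay. It keeps the core and the piperazine ring of compound 2 and differs only in one place: 2-methoxyphenyl in place of ethyl on an amine nitrogen in a ring. Among the measured compounds shown here, no pair of measured compounds differing in a single place is available, so there is no measured step from which to read the size of this change directly. On the shown data alone, the expectation for compound 3 is a modest move toward a lower number than compound 2, an estimated step of a 2.5-fold lower number from compound 2 to compound 3 (0.39 log units; beyond the scatter) in this assay. The estimate for compound 3 in this assay is 2000000 nM, with a range from 600000 nM to 6000000 nM.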

Compound 3, half-maximal inhibitory concentration: 4390000 nM
Compound 3: middle estimate off by 2.2-fold (0.34 log units), on the low side, within the range that was stated.
By their numbers in this assay, from the lowest: compound 1; then compounds 3 and 2 (each within the scatter of the next).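

In this assay, among the compounds shown here, the change reads as a 1.1-fold lower number from compound 2 to compound 3 (0.05 log units; within the scatter) and gives the first measured comparison of two compounds that differ in a single place. At this amine nitrogen in a ring, ethyl, with 2 heavy atoms and no ring, and 2-methoxyphenyl, with 8 heavy atoms, one six-membered aromatic ring and 1 hydrogen-bond acceptor, give values within the scatter of each other, so this larger group with its ring leaves no readable difference from ethyl here. No measurement of any property bears on this result, and nothing shown accounts for it.

The compounds shown leave open whether other groups on this nitrogen, such as a plain phenyl, a longer chain, a chain ending in a carboxylic acid or a chain ending in a primary amine, would also stay within the scatter of ethyl. With only ethyl and 2-methoxyphenyl shown at this place, a single step cannot tell whether the position tolerates change in general or whether these two groups merely happen to match.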